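Side-chain exchange from compound 2 to compound 3

This account rests on a few compounds, and the source may have more. Where it says the series, first, only, none or still open, it means among the compounds named here.

Compound 1 `COC(=O)CC/C=C\CC[C@H]1C(=O)C[C@@H](O)[C@@H]1/C=C/CC(C)(O)CCC1CC1` gives 0.00009 mg/kg
Compound 2 `COC(=O)CC/C=C\CC[C@H]1C(=O)C[C@@H](O)[C@@H]1/C=C/CC(C)(O)CCC1=CCCC1` gives 0.0001 mg/kg

In a functional assay on the whole organism (stomach) with Canis familiaris (Canis lupus familiaris) as the target (on this read-out higher numbers stand for an effect only at larger amounts of compound and lower numbers for an effect already at smaller amounts), compound 2 gives 0.0001 mg/kg and lies within the scatter of compound 1. Compound 3 `COC(=O)CC/C=C\CC[C@H]1C(=O)C[C@@H](O)[C@@H]1/C=C/C[C@@](C)(O)/C=C/C1(C)CC1` carries 1-hydroxy-1-methyl-3-(1-methylcyclopropyl)prop-2-en-1-yl in place of 3-(cyclopent-1-en-1-yl)-1-hydroxy-1-methylpropyl on a saturated chain carbon bound to a double-bonded chain carbon. Going by the values given here, the only measured step of a 1.1-fold higher number from compound 1 to compound 2 (0.05 log units; within the scatter) puts cyclopent-1-en-1-yl in place of cyclopropyl and stays within the scatter. Among the compounds with values here, no measured step covers the defined stereocentre. In this assay no shift beyond the scatter is expected, and the estimated step of no change at the digits printed from compound 2 to compound 3 (within the scatter) stays inside it. For compound 3 the expected value is 0.0001 mg/kg with an estimated range from 0.00002 mg/kg to 0.0008 mg/kg in these notes.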

Compound 3, dose for half-maximal effect: 0.00002 mg/kg
The estimate for compound 3 lay 5.0-fold (0.70 log units) above the measured number; the range from low to high includes it.
By their numbers in this assay, from the lowest: compound 3; then compounds 1 and 2 (each within the scatter of the next).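

In this assay, the side chain at this position now moves the number beyond the scatter (a 5.0-fold lower number from compound 2 to compound 3 (0.70 log units; beyond the scatter)), and the same holds against the saturated cyclopropyl chain (a 4.5-fold lower number from compound 1 to compound 3 (0.65 log units; beyond the scatter)). The earlier exchange of cyclopropyl for cyclopent-1-en-1-yl had shown no such shift, so this side chain tolerates change without loss and can also give a lower number. Nothing measured here bears on the reason for this shift.

The chain double bond, the 1-methylcyclopropyl group and the defined stereocentre all enter together in compound 3, so their separate contributions stay unresolved. Also open, as far as these compounds go, is how a phenyl ring or a longer chain would read in this place.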